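The source may hold more compounds than are shown below. What is called first, only, known or untested is meant among the compounds shown, and "the series" means these compounds.

Measured compounds:

Compound 1, `COc1cc(-c2cc(/C=C/C(=O)c3ccc(N)cc3)[nH]n2)cc(OC)c1OC`: in a functional assay on Malme-3M cells (Homo sapiens) for cytotoxicity, read by sulforhodamine B assay, with a stated time of 48 h, tested at 0.01 uM (on this read-out higher numbers stand for a weaker effect at the one concentration tested and lower numbers for a stronger effect), compound 1 gives 98%.
Compound 2, `COc1ccc(-c2cc(/C=C/C(=O)c3ccc(N)cc3)[nH]n2)cc1OC`: in this assay compound 2 gives 104%.
Compound 3, `COc1cc(C(=O)/C=C/c2cc(-c3cc(OC)c(OC)c(OC)c3)n[nH]2)cc(OC)c1OC`: in this assay compound 3 gives 100%.

All three numbers sit close together, and no two of them are separated by more than the usual scatter of this measurement, so none of the three can be called more or less active than another on this read-out. Among the measured compounds shown here, the only single-point change among the measured compounds is hydrogen in place of methoxy on an aromatic carbon, and it made a step of a number 6 percentage points higher from compound 1 to compound 2 (within the scatter), which is within the scatter. The difference between the core of compound 1 and the core of compound 3 is not broken down here; their two values simply lie within the scatter of each other.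

Compound 4, `COc1ccc(-c2cc(/C=C/C(=O)c3cc(OC)c(OC)c(OC)c3)[nH]n2)cc1OC`, has not yet been measured. It differs from compound 3 by hydrogen in place of methoxy on an aromatic carbon. The surroundings of the place where this change occurs are described in the same words as for the change from compound 1 to compound 2, so it is the same change, made on the core of compound 3 rather than the core of compound 1.

Because the earlier instance of this change gave a number 6 percentage points higher from compound 1 to compound 2 (within the scatter), a step within the scatter, the step from compound 3 to compound 4 is expected to be small as well, estimated as a number 2 percentage points higher from compound 3 to compound 4 (within the scatter). For compound 4 the expected value in this assay is therefore 102%, with an estimated range from 90% to 113%.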

Compound 4, a percentage reported as activity, at one concentration (the size of the read-out at that concentration, not a potency): 98%
Compound 4: the middle estimate sits 4 percentage points above what was measured; low and high end bracket the measured number.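

In this assay, among the compounds shown here, hydrogen in place of methoxy on an aromatic carbon now gives a number 2 percentage points lower from compound 3 to compound 4 (within the scatter), so this second instance of the change, like the first, produces no step that can be told apart from repeated measurement. Set side by side, the two instances do not differ on this read-out, and within this small series the change reads the same on the two cores: the same change on two cores in this assay, a number 6 percentage points higher (within the scatter) from compound 1 to compound 2 and a number 2 percentage points lower (within the scatter) from compound 3 to compound 4, 8 percentage points apart, within the scatter of two such steps This shows only that the change stays within the scatter on both cores at the single concentration tested; it does not show that the methoxy group is without any influence, and it gives no size of effect that could be carried to a further core, since neither step rises beyond the scatter.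

The compounds shown have only methoxy or hydrogen at this place, so it remains open how a hydroxyl group, an amine or a longer alkoxy chain there would read in this assay. Going by these compounds, it also remains open whether the two cores would still respond alike to this change at another concentration or in another cell line.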